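Carboxy in place of morpholine amide: growth inhibition notes

A few compounds are considered here, and "the series" means these few. Any claim that something is new, unique, unknown or untested is made for them only; others in the source may bear on it.

Measured so far in a functional assay on HCT-116 cells (Homo sapiens) for inhibition, read by MTT assay, with a stated time of 72 h; a lower number here means a stronger inhibitor of growth, a higher number a weaker inhibitor of growth:
- compound 1 `CCOC(=O)/C=C/c1ccncc1-c1ccc2c(cnn2C)c1`: 1330 nM
- compound 2 `Cn1ncc2cc(-c3cnccc3/C=C/C(=O)N3CCOCC3)ccc21`: "not determined" (no result reported)

Compound 2 has no number in this assay, so its place in the series cannot be ranked against compound 1. Among the compounds with values here, the only anchor is compound 1 at 1330 nM. Next for testing is compound 3 `Cn1ncc2cc(-c3cnccc3/C=C/C(=O)O)ccc21`.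

The structural change is hydroxy in place of morpholin-4-yl on a carbonyl carbon. Hydroxy stands in place of morpholin-4-yl on a carbonyl carbon, which reads one bond further out as (morpholin-4-yl)carbonyl to carboxy. The core and the double-bonded chain carbon stay the same.

Within the data shown here, no measured step shows what this change does, and the step itself has no measured starting value. The expectation is therefore a judgement: a result on the weaker side of the compound 1 value, by a moderate step beyond the usual scatter, with a wide margin. A result reported only as a limit is also possible.

For compound 3 the expected value in this assay is 5000 nM, with an estimated range of 1500 nM to 25000 nM.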

Compound 3, concentration for 50% growth inhibition: > 30000 nM
Compound 3: only a limit was reported; the forecaster's own chance of this, stated with the estimate: 25%; middle value at least 6.0-fold (0.77 log units) away from the limit.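

Within the data shown here, compound 3 supplies the first measured step: in this assay, hydrogen in place of ethyl on an oxygen next to a carbonyl group gives an at least 22-fold higher number from compound 1 to compound 3 (1.35 log units; beyond the scatter). Among these compounds, this is the first sign that the end of this chain can matter strongly for growth inhibition, with the ethyl ester, compound 1, giving 1330 nM and the carboxy compound reaching no measurable value. Going by these compounds, the reading for compound 3, > 30000 nM, is a limit and not a number, so the step gives only a minimum size and its full size stays unknown: the limit of > 30000 nM in this assay, at which 1 of the 3 values shown sits.

The step from compound 2 to compound 3 cannot be read, so the morpholin-4-yl amide has no place relative to either the carboxy compound or the ethyl ester. Still open, on these data alone, is whether the ethyl group itself matters or any capped carbonyl would serve, a question that a methyl ester, a longer alkyl ester or a primary amide on the same chain would address in this assay.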